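A few compounds are considered here, and "the series" means these few. Any claim that something is new, unique, unknown or untested is made for them only; others in the source may bear on it.

Compound 1, `COc1cc(/C=C/C(=O)/C=C/c2cc(OC)c(OC)c(OC)c2)ccc1OCc1cn(CCOc2cc(=O)oc3ccccc23)nn1`, gives 99% in a functional assay on THP-1 cells (Homo sapiens) for inhibition, read by sulforhodamine B assay, with a stated time of 48 h, tested at 50 uM (on this read-out lower numbers stand for less inhibition of growth and higher numbers for more inhibition of growth at the one concentration tested), the highest of the three numbers in hand. Compound 2, `COc1cc(/C=C/C(=O)/C=C/c2cccc3ccccc23)ccc1OCc1cn(CCCOc2cc(=O)oc3ccccc23)nn1`, gives 71% in this assay, and compound 3, `COc1cc(/C=C/C(=O)/C=C/c2cccc3ccccc23)ccc1OCc1cn(CCCCCOc2cc(=O)oc3ccccc23)nn1`, gives 44% in this assay, so compound 1 stands beyond the scatter above both of them. Compound 4, `COc1cc(/C=C/C(=O)/C=C/c2ccccc2)ccc1OCc1cn(CCOc2cc(=O)oc3ccccc23)nn1`, is still to be measured; it differs from compound 1 by phenyl in place of 3,4,5-trimethoxyphenyl on a double-bonded chain carbon bound to a double-bonded chain carbon. Among the measured compounds shown here, no pair of measured compounds isolates this change, so nothing in hand shows its effect directly. Because compound 1 already sits at the top with 99%, a downward step beyond the scatter is expected, estimated as a number 29 percentage points lower from compound 1 to compound 4 (beyond the scatter) in this assay. Compound 4 is therefore expected to give 70%, within a range of 40% to 95%.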

Compound 4, percent growth inhibition at one concentration: 61%
Compound 4: middle estimate off by 9 percentage points, on the high side; the range from low to high includes it.
By their numbers in this assay, from the lowest: compound 3; then compounds 4 and 2 (each within the scatter of the next); then compound 1.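

Phenyl in place of 3,4,5-trimethoxyphenyl on a double-bonded chain carbon bound to a double-bonded chain carbon gives in this assay the first direct reading of this change: a number 38 percentage points lower from compound 1 to compound 4 (beyond the scatter) and thus a large loss of growth inhibition. In this pair, the 3,4,5-trimethoxyphenyl group therefore goes with the higher number. Nothing measured here explains the step. As far as these compounds go, whether a single methoxy group or an amine on that ring would restore the inhibition remains open. So does whether this step would hold with a longer chain.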